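The source may hold more compounds than are shown below. What is called first, only, known or untested is meant among the compounds shown, and "the series" means these compounds.

Compound 1, `N/C(CC(O)c1cccc2ccccc12)=N\N=C\c1ccc(Cl)c(Cl)c1`, gives 16000 nM in an ADME assay on L6 cells (Rattus norvegicus) for cytotoxicity, read by resazurin assay, with a stated time of 72 h; a higher number here means a weaker inhibitor, a lower number a stronger inhibitor. Compound 2, `N/C(CC(O)c1cccc2ccccc12)=N\N=C\c1ccc(F)cc1`, gives 19000 nM in this assay. Compound 3, `N/C(CC(O)c1ccc2ccccc2c1)=N\N=C\c1ccc(F)cc1`, reaches only > 298000 nM in this assay, which is a limit of the assay and not a number.

Compound 2 and compound 1 share a core and differ by 3,4-dichlorophenyl in place of 4-fluorophenyl on a carbon with a double bond to nitrogen. That change made a 1.2-fold lower number from compound 2 to compound 1 (0.07 log units; within the scatter). Compound 3 carries a different core; how the two cores differ is not broken down here. Compound 4, `N/C(CC(O)c1ccc2ccccc2c1)=N\N=C\c1ccc(Cl)c(Cl)c1`, has not yet been measured in this assay. It differs from compound 3 by 3,4-dichlorophenyl in place of 4-fluorophenyl on a carbon with a double bond to nitrogen, the same change, at the same place. Because the measured step was a 1.2-fold lower number from compound 2 to compound 1 (0.07 log units; within the scatter), the step from compound 3 to compound 4 is expected to be a step that the limit leaves unreadable from compound 3 to compound 4, and compound 4 is expected to sit near 300000 nM, most likely again only as a limit.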

Compound 4, half-maximal inhibitory concentration: 100000 nM
Compound 4: middle estimate off by 3.0-fold (0.48 log units), on the high side, outside the stated range (below it).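

In this assay, putting 3,4-dichlorophenyl in place of 4-fluorophenyl gave an at least 2.9-fold lower number from compound 3 to compound 4 (0.47 log units; beyond the scatter), so on this core the change leaves a step beyond the scatter. This does not show whether the change acts to the same extent on both cores: the same change on two cores in this assay, a 1.2-fold lower number (0.07 log units; within the scatter) from compound 2 to compound 1 and an at least 2.9-fold lower number (0.47 log units; beyond the scatter) from compound 3 to compound 4; the limit leaves it open whether they differ. Compound 3, the starting point of this step, has only a limit of the assay and not a number: the limit of > 298000 nM in this assay, at which 1 of the 4 values shown sits.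

The compounds shown leave open what an amine or a carboxylic acid would do at this place in this assay. They also leave open how far the step from compound 3 to compound 4 really reaches.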